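Chloromethyl for dichlorophenyl on the acylated amine

This account rests on a few compounds, and the source may have more. Where it says the series, first, only, none or still open, it means among the compounds named here.

Compound 1 `O=C(CSc1nnc(NC(=O)c2c(Cl)cccc2Cl)s1)Nc1ccc(Br)cn1` gives 16800 nM in a functional assay on NCI-H460 cells (Homo sapiens) for antiproliferative activity, read by MTT assay, with a stated time of 48 h (a higher number here means a weaker inhibitor, a lower number a stronger inhibitor), and is the only one of the three measured compounds that returns a number. Compound 2 `COc1ccccc1C(=O)Nc1nnc(SCC(=O)Nc2ccc(Cl)cn2)s1` reaches only the limit > 80000 nM in this assay. Compound 3 `COc1ccccc1C(=O)Nc1nnc(SCC(=O)Nc2c(C)ccnc2Cl)s1` likewise reaches only the limit > 80000 nM in this assay. Going by the values given here, the single step that can be drawn between measured compounds, a step that the two limits leave unreadable from compound 2 to compound 3, stays unreadable since both of its ends sit at the limit of > 80000 nM in this assay, at which 2 of the 3 values shown sit. On the numbers shown compound 1 thus stands alone as the sole readable potency in the series.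

Compound 4 `O=C(CSc1nnc(NC(=O)CCl)s1)Nc1ccc(Br)cn1` differs from compound 1 by chloromethyl in place of 2,6-dichlorophenyl on a carbonyl carbon. Among the compounds with values here, no measured step touches this change: the step from compound 2 to compound 3 alters the group on the amide-type nitrogen, not the group on this carbonyl carbon, and it cannot be read in any case. Within the data shown here, with no comparable step available, the expected outcome in this assay is a step of unknown direction, and the estimate is set close to compound 1 with a wide range. Compound 4 is expected at 20000 nM (range 5000 nM to 80000 nM), an expected step of a 1.2-fold higher number from compound 1 to compound 4 (0.08 log units; within the scatter).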

Compound 4, half-maximal inhibitory concentration: 7500 nM
Beside the measured number, compound 4's estimate is 2.7-fold (0.43 log units) above it; low and high end bracket the measured number.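

In this assay, going by these compounds alone, this position gives the first readable step, a 2.2-fold lower number from compound 1 to compound 4 (0.35 log units; beyond the scatter), with chloromethyl in place of 2,6-dichlorophenyl on a carbonyl carbon and the rest of compound 1 unchanged. A six-membered aromatic ring at this position is therefore not needed for a measurable antiproliferative value, and the smaller group with no ring gives a modestly stronger result. Nothing measured among these compounds accounts for the step.

This one pair cannot show whether the step follows from losing the ring or from the chloromethyl group itself. Methyl, aminomethyl or unsubstituted phenyl on the same carbonyl carbon would separate those readings, and it remains open whether the step holds with a group other than the 5-bromopyridin-2-yl amide.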